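A few compounds are considered here, and "the series" means these few. Any claim that something is new, unique, unknown or untested is made for them only; others in the source may bear on it.

Compound 2, with the structure `O=C(/C=C/C=C/c1ccccc1)c1cc(Cl)ccc1O`, gives 54.8 nM in an in vitro assay on cells for inhibition of Amine oxidase [flavin-containing] B (Homo sapiens), read by Amplex Red, with a stated time of 15 min; a higher number here means a weaker inhibitor, a lower number a stronger inhibitor. Compound 1, `COc1ccc(/C=C/C=C/C(=O)c2cc(Cl)ccc2O)cc1`, carries one change against compound 2, namely (methoxy in place of hydrogen on an aromatic carbon), and in this assay compound 1 gives 153 nM, so that the change made a 2.8-fold higher number from compound 2 to compound 1 (0.45 log units; beyond the scatter). Compound 3, `COc1cc(/C=C/C=C/C(=O)c2ccccc2O)ccc1O`, shares no single counted difference with compound 2; the difference between the two cores is not broken down here. In this assay compound 3 gives 502 nM, the highest number among the three measured compounds.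

Compound 4, `COc1cc(/C=C/C=C/C(=O)c2c(O)cccc2OC)ccc1O`, has not been measured. It differs from compound 3 by methoxy in place of hydrogen on an aromatic carbon. For the measured compounds named here, this is the same kind of change as the one from compound 2 to compound 1, but the surroundings are not the same: there the entering group sat para to a large group, here it sits ortho to a large group and meta to a hydroxy group. Going by the values given here, with only one earlier example of such a change, and that in a different setting, the step is expected to be of a similar, modest size, estimated as a 2.4-fold higher number from compound 3 to compound 4 (0.38 log units; beyond the scatter). On that basis compound 4 is expected to give about 1200 nM in this assay, with a plausible range from 400 nM to 3500 nM.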

Compound 4, half-maximal inhibitory concentration: 486 nM
Estimate against measurement, compound 4: 2.5-fold (0.39 log units) above; low and high end bracket the measured number.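

In this assay, for the compounds shown here, methoxy in place of hydrogen on an aromatic carbon gave a 1.0-fold lower number from compound 3 to compound 4 (0.01 log units; within the scatter) and so left no step that can be told from the scatter. Set beside the earlier case, the same change did not carry over with the same size from one core to the other: the same change on two cores in this assay, a 2.8-fold higher number (0.45 log units; beyond the scatter) from compound 2 to compound 1 and a 1.0-fold lower number (0.01 log units; within the scatter) from compound 3 to compound 4, 2.9-fold (0.46 log units) apart, beyond the scatter of two such steps. Going by these compounds alone, this shows that a step read on one core of this series cannot simply be transferred to another, but it rests on only two pairs, which differ both in the core and in the place of the entering methoxy, so it does not show which of these two differences accounts for the gap, nor what a third core would do.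

The compounds shown leave open how methoxy would read at the same place on the core of compound 1 and at the other place on the core of compound 3. They also leave open whether an amine, a carboxylic acid or a longer chain at the entering position would read any differently from methoxy in this assay.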